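Bromo for Nitro on a Nitrile-Bearing Pyran Core

The source may report more compounds than this note shows. Statements on the series, on what has been measured and on what is new or still open speak of the compounds shown alone.

Compound 1 `N#CCC(=O)N/N=C(/CBr)c1ccc(Br)cc1` gives 10000 nM in a functional assay on NCI-H460 cells (Homo sapiens) for inhibition, read by sulforhodamine B assay, with a stated time of 48 h; a higher number here means a weaker inhibitor of growth, a lower number a stronger inhibitor of growth.
Compound 2 `N#CCC(=O)N/N=C(/CBr)c1ccc([N+](=O)[O-])cc1` gives 10300 nM in this assay.
Compound 3 `N#CCC1=C(C#N)CC(c2ccc([N+](=O)[O-])cc2)=C(CC(=O)c2ccc([N+](=O)[O-])cc2)O1` gives 80 nM in this assay.

Compounds 1 and 2 share a small hydrazone core and differ only by bromo in place of nitro on an aromatic carbon; this change gives a 1.0-fold lower number from compound 2 to compound 1 (0.01 log units; within the scatter), so the two numbers cannot be told apart. Compound 3 has a different, larger core; the difference between the two cores is not broken down here, and compound 3 stands far from both.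

Compound 4 `N#CCC1=C(C#N)CC(c2ccc([N+](=O)[O-])cc2)=C(CC(=O)c2ccc(Br)cc2)O1` has not been measured. It differs from compound 3 by bromo in place of nitro on an aromatic carbon, the same change as between compounds 2 and 1, at a place described in the same words. Because a 1.0-fold lower number from compound 2 to compound 1 (0.01 log units; within the scatter) lies within the scatter, the step from compound 3 to compound 4 is expected to be a 1.1-fold higher number from compound 3 to compound 4 (0.05 log units; within the scatter). Compound 4 is therefore estimated at 90 nM in this assay, expected between 35 nM and 250 nM.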

Compound 4, concentration for 50% growth inhibition: 3600 nM
Estimate against measurement, compound 4: 40-fold (1.60 log units) below, and the stated range ends below it.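

Replacing nitro with bromo matters greatly on the larger core in this assay, where the change gives a 45-fold higher number from compound 3 to compound 4 (1.65 log units; beyond the scatter). The result on the smaller core therefore does not carry over to this one, as the two steps set side by side show: the same change on two cores in this assay, a 1.0-fold lower number (0.01 log units; within the scatter) from compound 2 to compound 1 and a 45-fold higher number (1.65 log units; beyond the scatter) from compound 3 to compound 4, 46-fold (1.67 log units) apart, beyond the scatter of two such steps. Within the data shown here, this rests on only one pair of compounds per core, so it shows that the effect of this change depends on the core, but not why, nor what it would do on a third core.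

The compounds shown leave open how other groups at this place, such as an amine or a carboxylic acid, would read. They also leave open what changing the second 4-nitrophenyl group, which compound 4 keeps, would do.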